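An Allyloxy Group on the Plain Ring of Compound 2

The source may report more compounds than this note shows. Statements on the series, on what has been measured and on what is new or still open speak of the compounds shown alone.

Compound 2 `CCc1ccccc1-c1n[nH]c(-c2ccccc2)n1` gives the lowest of two numbers in a functional assay on the whole organism (Cricetulus griseus) with Cricetinae gen. sp. as the target (a lower number here means that less compound is needed, a higher number that more compound is needed for the effect), namely 0.15 mg/kg. Its nearest neighbour is compound 3 `CCCCc1ccccc1-c1n[nH]c(-c2ccccc2)n1`, which gives 17 mg/kg in this assay; the step of a 110-fold higher number from compound 2 to compound 3 (2.05 log units; beyond the scatter) is large. Compound 1 `Cc1ccccc1-c1n[nH]c(-c2ccccc2)n1` gives 0.3 mg/kg; 0.3 mg/kg (2 entries) in this assay. Compound 4 `C=CCOc1cccc(-c2nc(-c3ccccc3CC)n[nH]2)c1` differs from compound 2 by allyloxy in place of hydrogen on an aromatic carbon, meta to a large group. Among the measured compounds shown here, no measured step touches that ring: the only known step, the ethyl added to the chain, lies elsewhere and gives weak guidance, so any expectation is uncertain. A modest rise in dose is expected for compound 4, estimated at 0.5 mg/kg with a range from 0.1 mg/kg to 4 mg/kg. The expected step is a 3.3-fold higher number from compound 2 to compound 4 (0.52 log units; beyond the scatter).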

Compound 4, dose for half-maximal effect: 0.12 mg/kg
The estimate for compound 4 lay 4.2-fold (0.62 log units) above the measured number, and the stated range covers the measured number.
By their numbers in this assay, from the lowest: compounds 4 and 2 (each within the scatter of the next); then compound 3.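

On the plain ring, allyloxy in place of hydrogen on an aromatic carbon, meta to a large group, leaves compound 4 indistinguishable from compound 2 in this assay: the step is a 1.3-fold lower number from compound 2 to compound 4 (0.10 log units; within the scatter). Among the compounds shown here, this place therefore accepts a group of this size without a measurable loss, which the earlier compounds could not show, since their only step, a 110-fold higher number from compound 2 to compound 3 (2.05 log units; beyond the scatter), lies on the ethyl chain of the other ring.

Going by these compounds, whether an amine or a carboxylic acid in the same place would behave like allyloxy remains open. Nothing at hand explains why allyloxy is accepted here.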